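A Ring Nitrogen Swap in a Weakly Antiproliferative Series

The source may hold more compounds than are shown below. What is called first, only, known or untested is meant among the compounds shown, and "the series" means these compounds.

The measured compounds in a functional assay on HeLa cells (Homo sapiens) for antiproliferative activity, read by sulforhodamine B assay, with a stated time of 48 h (on this read-out lower numbers stand for stronger inhibition and higher numbers for weaker inhibition), are:

compound 1, `COc1ccc(CNC(=O)/C=C/C=C/[C@H](O)Cc2ccc(OC)c(OC)c2)cc1`, 9450 nM
compound 2, `COc1ccc(C[C@@H](O)/C=C/C=C/C(=O)N2CCN(c3ccccn3)CC2)cc1OC`, 23600 nM
compound 3, `CCNC(=O)/C=C/C=C/[C@H](O)Cc1ccc(OC)c(OC)c1`, 14600 nM

Compound 2 has the highest number of the three. Its nearest neighbour is compound 3, whose number is lower by an amount that stays within the scatter, while compound 1 lies further away, beyond the scatter. For the measured compounds named here, the only single-place step among the measured compounds is a 1.5-fold higher number from compound 1 to compound 3 (0.19 log units; within the scatter), a change at the amide end that barely moves the read-out.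

Compound 4, `COc1ccc(C[C@@H](O)/C=C/C=C/C(=O)N2CCN(c3ncccn3)CC2)cc1OC`, has not yet been measured. It differs from compound 2 in one place: pyrimidin-2-yl in place of pyridin-2-yl on an amine nitrogen in a ring. Going by the values given here, no measured step touches the group on that ring nitrogen, so nothing here speaks for a shift in either direction; the one measured step concerns a different position and was itself small. Compound 4 is therefore expected to sit close to compound 2, with an expected step of a 1.0-fold higher number from compound 2 to compound 4 (0.01 log units; within the scatter). The estimate for compound 4 in this assay is 24000 nM, within a range from 9000 nM to 65000 nM.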

Compound 4, half-maximal inhibitory concentration: 12600 nM
Compound 4: the middle estimate sits 1.9-fold (0.28 log units) above what was measured; the range from low to high includes it.
By their numbers in this assay, from the lowest: compounds 1, 4, 3 and 2 (each within the scatter of the next, the first and the last beyond it).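

For the compounds shown here, this is the first measured step at the amine nitrogen in the ring. In this assay, pyrimidin-2-yl in place of pyridin-2-yl gives a 1.9-fold lower number from compound 2 to compound 4 (0.27 log units; within the scatter) and so shows that a second ring nitrogen in this six-membered aromatic group, which raises the count of hydrogen-bond acceptors from 1 to 2 at the same 6 heavy atoms, leaves the read-out within the usual scatter. No measurement shown here explains the size of this step.

The compounds shown leave open how phenyl, with no hetero atom in its ring, or an open-chain group such as acetyl would read on that same ring nitrogen. They also leave open whether pyrazin-2-yl, a further six-membered aromatic ring with 2 hetero atoms, would read like pyrimidin-2-yl.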